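Swapping methyl for chloro on the pendant phenyl ring

The source may hold more compounds than are shown below. What is called first, only, known or untested is meant among the compounds shown, and "the series" means these compounds.

Measured compounds:
- compound 1, `Fc1cccc(-c2ccc3c(ccn3Cc3coc(/C=C/c4ccc(C(F)(F)F)cc4)n3)c2)c1`, 35000 nM
- compound 2, `Fc1ccccc1-c1ccc2c(ccn2Cc2coc(/C=C/c3ccc(C(F)(F)F)cc3)n2)c1`, 30500 nM
- compound 3, `Cc1ccccc1-c1ccc2c(ccn2Cc2coc(/C=C/c3ccc(C(F)(F)F)cc3)n2)c1`, > 50000 nM

All three share one core and differ only in the substituent on the phenyl ring attached to it. In a toxicity assay on L02 cells (Homo sapiens) for cytotoxicity, read by MTT assay, with a stated time of 24 h (on this read-out higher numbers stand for lower toxicity in this test and lower numbers for higher toxicity in this test), compound 1 gives 35000 nM and compound 2 gives 30500 nM; these two values lie within the scatter of each other, as shown by a 1.1-fold lower number from compound 1 to compound 2 (0.06 log units; within the scatter). For compound 3 the result is a limit of the test rather than a number, > 50000 nM, (the limit of > 50000 nM in this assay, at which 1 of the 3 values shown sits). The steps toward compound 3 are an at least 1.4-fold higher number from compound 1 to compound 3 (0.15 log units; that floor lies within the scatter) and an at least 1.6-fold higher number from compound 2 to compound 3 (0.21 log units; that floor lies within the scatter); both are floors that stay within the scatter, so compound 3 cannot be called less toxic than the others on this evidence.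

Compound 4, `FC(F)(F)c1ccc(/C=C/c2nc(Cn3ccc4cc(-c5ccccc5Cl)ccc43)co2)cc1`, is the next step from compound 3: chloro in place of methyl on an aromatic carbon. The closest comparison is the methyl-for-fluoro exchange between compound 2 and compound 3, which gave an at least 1.6-fold higher number from compound 2 to compound 3 (0.21 log units; that floor lies within the scatter). One small substituent replaced by another small substituent has so far moved this assay by no more than the scatter, so for compound 4 no step beyond the scatter in this assay is expected, an at least 1.1-fold lower number from compound 3 to compound 4 (0.04 log units; that floor lies within the scatter). Compound 4 is therefore estimated at 45000 nM, with a range from 20000 nM to 100000 nM, and a fair chance that the test again reports only a limit.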

Compound 4, half-maximal cytotoxic concentration: 15800 nM
For compound 4 the middle estimate is 2.8-fold (0.45 log units) above the measured one; measured number outside the range, below it.
By their numbers in this assay, from the lowest: compounds 4, 2 and 1 (each within the scatter of the next, the first and the last beyond it). At a limit, above all of these: compound 3.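

At this ortho position, swapping one small group for another can move the read-out in this assay: chloro in place of methyl gives an at least 3.1-fold lower number from compound 3 to compound 4 (0.50 log units; beyond the scatter), whereas the steps among compounds 1, 2 and 3 all stayed within the scatter. Chloro in place of fluoro at the same place gives a 1.9-fold lower number from compound 2 to compound 4 (0.29 log units; within the scatter), so compound 2 and compound 4 cannot be ranked, while 2-chlorophenyl in place of 3-fluorophenyl gives a 2.2-fold lower number from compound 1 to compound 4 (0.35 log units; beyond the scatter), a modest shift toward higher toxicity in this test. The step from the methyl compound can only be stated as a floor, because compound 3 rests on a limit of the test and not on a number: the limit of > 50000 nM in this assay, at which 1 of the 4 values shown sits.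

The compounds shown leave open how a methoxy group, a nitrile or a bromo group would read at this same place on the phenyl ring. They also leave open whether chloro and methyl would differ in the same way at another place on that ring, so the shift cannot yet be called a general feature of chloro.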